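Aryl variation on the triazole nitrogen: compound 4

A few compounds are considered here, and "the series" means these few. Any claim that something is new, unique, unknown or untested is made for them only; others in the source may bear on it.

Measured so far in a functional assay on A549 cells (Homo sapiens) for antiproliferative activity, read by MTT assay, with a stated time of 48 h; a higher number here means a weaker inhibitor, a lower number a stronger inhibitor:
compound 1 `Cc1cccc(-n2nncc2CN2C(=O)C3(C(C#N)=C(N)Oc4c(N)cc5nc6ccccc6nc5c43)c3ccccc32)c1` gives 12300 nM
compound 2 `N#CC1=C(N)Oc2c(N)cc3nc4ccccc4nc3c2C12C(=O)N(Cc1cnnn1-c1cccc(Br)c1)c1ccccc12` gives 18900 nM
compound 3 `COc1ccccc1-n1nncc1CN1C(=O)C2(C(C#N)=C(N)Oc3c(N)cc4nc5ccccc5nc4c32)c2ccccc21` gives 37500 nM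

Compound 3 has the highest number of the three in this assay. Its gap to compound 2 is within the scatter; its gap to compound 1, a 3.0-fold higher number from compound 1 to compound 3 (0.48 log units; beyond the scatter), is beyond it, though modest.

Compound 4 `Cc1ccc(-n2nncc2CN2C(=O)C3(C(C#N)=C(N)Oc4c(N)cc5nc6ccccc6nc5c43)c3ccccc32)cc1C` differs from compound 3 in one place: 3,4-dimethylphenyl in place of 2-methoxyphenyl on an aromatic nitrogen. The change undoes the methoxy-to-methyl swap seen between compound 1 and compound 3 and adds a second methyl on the ring. Going by the values given here, two measured steps bear on it. a 3.0-fold higher number from compound 1 to compound 3 (0.48 log units; beyond the scatter) shows that moving from 3-methylphenyl to 2-methoxyphenyl raised the number; a 2.0-fold higher number from compound 2 to compound 3 (0.30 log units; within the scatter) shows a smaller rise from 3-bromophenyl that stays within the scatter. Returning to a methyl-bearing phenyl is therefore expected to bring the number back down toward that of compound 1; the second methyl has no precedent here, so no further movement is assumed.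

Compound 4 is expected to give 12000 nM in this assay, with a likely range of 5000 nM to 30000 nM. The step this estimate implies, a 3.1-fold lower number from compound 3 to compound 4 (0.49 log units; beyond the scatter), is expected to be a lowering of about the size of the reverse of the compound 1 to compound 3 step.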

Compound 4, half-maximal inhibitory concentration: > 50000 nM
Compound 4 gave a limit, no number; the forecaster's own chance of this, stated with the estimate: 5%; middle value at least 4.1-fold (0.61 log units) away from the limit.
By their numbers in this assay, from the lowest: compounds 1, 2 and 3 (each within the scatter of the next, the first and the last beyond it). At a limit, above all of these: compound 4.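

In this assay compound 4 stands at a limit of the assay and not at a number: the limit of > 50000 nM in this assay, at which 1 of the 4 values shown sits. The single added methyl on the ring that separates it from compound 1 gives an at least 4.0-fold higher number from compound 1 to compound 4 (0.60 log units; beyond the scatter), whereas the bromo-for-methyl step between compound 1 and compound 2 stayed within the scatter, so this aryl group on the aromatic nitrogen is less forgiving of change than the first three compounds suggested. Against the other two analogues, an at least 2.6-fold higher number from compound 2 to compound 4 (0.42 log units; beyond the scatter) clears the scatter, while an at least 1.3-fold higher number from compound 3 to compound 4 (0.12 log units; that floor lies within the scatter) means that the 2-methoxyphenyl and 3,4-dimethylphenyl groups cannot yet be firmly separated, and the true size of all three steps remains unknown.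

What the compounds shown leave open is whether the second methyl itself drives the rise or whether any further group on this ring would do the same, for instance an amine or a carboxylic acid in its place. They also leave open how an unsubstituted phenyl at this nitrogen would read in this assay, which would give the series a baseline for every substituent so far.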